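Methyl to methoxy on the shared core: a second instance

This account rests on a few compounds, and the source may have more. Where it says the series, first, only, none or still open, it means among the compounds named here.

Measured in a functional assay on MCF7 cells (Homo sapiens) for cytotoxicity, read by CellTiter-Glo, with a stated time of 5 days; a higher number here means a weaker inhibitor, a lower number a stronger inhibitor:
compound 1 `CC/C(=C(\c1ccc2[nH]ncc2c1)c1ccc(/C=C/C(=O)O)cc1C)c1ccccc1` gives 36 nM
compound 2 `CC/C(=C(/c1ccc(/C=C/C(=O)O)c(C)c1)c1ccc2[nH]ncc2c1)c1ccccc1` gives 14 nM
compound 3 `CC/C(=C(\c1ccc2[nH]ncc2c1)c1ccc(/C=C/C(=O)O)cc1OC)c1ccccc1` gives 12 nM

Compound 1 and compound 2 are built from the same atoms joined differently; the difference between the two cores is not broken down here. In this assay compound 2 sits between the other two: the gap to compound 3 is within the scatter, so no order between them is claimed, while the gap to compound 1 is beyond it.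

Among the measured compounds shown here, the one counted step is methoxy in place of methyl on an aromatic carbon, which gives a 3.0-fold lower number from compound 1 to compound 3 (0.48 log units; beyond the scatter). The unmeasured compound 4 `CC/C(=C(/c1ccc(/C=C/C(=O)O)c(OC)c1)c1ccc2[nH]ncc2c1)c1ccccc1` repeats the same kind of change on the core of compound 2: methoxy in place of methyl on an aromatic carbon. The surroundings are not identical. In the step from compound 1 to compound 3 the changed carbon is ortho to a large group and meta to a 2-carboxyethenyl group; in the step from compound 2 to compound 4 it is ortho to a 2-carboxyethenyl group and meta to a large group. With a single precedent and a shifted place, the expectation is a step in the same direction but taken with less weight.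

Compound 4 is expected to give 7 nM in this assay, the step of a 2.0-fold lower number from compound 2 to compound 4 (0.30 log units; within the scatter) being a softened copy of a 3.0-fold lower number from compound 1 to compound 3 (0.48 log units; beyond the scatter), with a range of 2.5 nM to 22 nM.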

Compound 4, half-maximal inhibitory concentration: 31 nM
The estimate for compound 4 lay 4.4-fold (0.65 log units) below the measured number; measured number above the stated range.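

In this assay, methoxy in place of methyl on an aromatic carbon gives a 2.2-fold higher number from compound 2 to compound 4 (0.35 log units; beyond the scatter). Set beside the earlier step, this shows that the change does not carry from one core to the other with a fixed direction or size, so a step measured on one of these cores is a poor guide to the same change on the other: the same change on two cores in this assay, a 3.0-fold lower number (0.48 log units; beyond the scatter) from compound 1 to compound 3 and a 2.2-fold higher number (0.35 log units; beyond the scatter) from compound 2 to compound 4, 6.6-fold (0.82 log units) apart, beyond the scatter of two such steps

What this does not show is the reason for the reversal: the two steps differ both in the core and in the surroundings of the changed carbon, which on the core of compound 2 is ortho to a 2-carboxyethenyl group and meta to a large group, and two steps cannot separate those factors or give a rule for any further core.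

The compounds shown leave open whether the reversal is particular to methoxy or also appears with other groups on the same carbon, such as ethoxy, ethyl or chlorine. Also open, from the compounds shown here alone, is how methyl and methoxy would each compare with plain hydrogen at that carbon on the two cores, which would show which of the two groups drives each step.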